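Sec-butyl in place of phenyl on a five-membered ring

The compounds below may be only part of what the source reports. "The series", "measured", "known", "first", "only" and "open" are said of these compounds alone.

compound 1, `CCC(C)C(NC(=O)NO)C(=O)NC1CCCCC1`: 150000 nM
compound 2, `O=C1NC(c2ccccc2)C(=O)N1Cc1ccccc1`: > 200000 nM, a limit of the assay

In a functional assay on MOLT-4 cells (Homo sapiens) for inhibition (on this read-out higher numbers stand for weaker inhibition and lower numbers for stronger inhibition), compound 1 gives 150000 nM. Compound 2 gives only > 200000 nM, which is a limit of the assay and not a number. The two compounds share no single-point change, so their values are only set side by side here: one weak number and one limit, with the limit of > 200000 nM in this assay, at which 1 of the 2 values shown sits, marking where compound 2 sits.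

Compound 3 is `CCC(C)C1NC(=O)N(Cc2ccccc2)C1=O`. It differs from compound 2 in one place: sec-butyl in place of phenyl on a saturated ring carbon. Compound 3 thus keeps the ring system of compound 2 and the benzyl on the ring nitrogen, while carrying the sec-butyl seen in the open-chain compound 1.

Within the data shown here, no measured step informs the size of this change. Among the measured compounds shown here, compound 2 gives only a limit, and compound 1, the only other compound with a number, is itself weak in this assay. Compound 3 is therefore expected to stay near the limit, with the step from compound 2 to compound 3 estimated as a number no higher from compound 2 to compound 3 (the limit leaves the size open). The estimate for compound 3 is 200000 nM, within 80000 nM to 500000 nM.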

Compound 3, half-maximal inhibitory concentration: > 200000 nM
Compound 3 was reported as a limit; the forecaster's own chance of this, stated with the estimate: 70%; the middle value lies on the limit itself.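

In this assay compound 3 gives > 200000 nM, which is a limit of the assay and not a number. Compound 2 is also reported only as a limit, so no step can be read between compound 2 and compound 3. The compounds shown leave open how sec-butyl and phenyl on this saturated ring carbon compare in this assay.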